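Vinyl for pyridin-4-yl on a shared indole-oxazole core

The source may hold more compounds than are shown below. What is called first, only, known or untested is meant among the compounds shown, and "the series" means these compounds.

Compound 1 `Fc1ccc(-c2nc(-c3c[nH]c4ccccc34)co2)cc1` gives 28000 nM in a functional assay on MCF7 cells (Homo sapiens) for cytotoxicity, read by MTT assay, with a stated time of 48 h; a lower number here means a stronger inhibitor, a higher number a weaker inhibitor.
Compound 2 `c1ccc2c(-c3coc(-c4ccncc4)n3)c[nH]c2c1` gives 54900 nM in this assay.

Compound 2 holds the highest of the two numbers, and the nearest is compound 1, with a 2.0-fold higher number from compound 1 to compound 2 (0.29 log units; within the scatter). Compound 3 `C=Cc1nc(-c2c[nH]c3ccccc23)co1` differs from compound 2 by vinyl in place of pyridin-4-yl on an aromatic carbon. For the measured compounds named here, only one measured step touches this position, and it lay within the scatter, so no direction is expected beyond the scatter for compound 3 in this assay. Compound 3 is expected to give 60000 nM, between 18000 nM and 200000 nM, an estimated step of a 1.1-fold higher number from compound 2 to compound 3 (0.04 log units; within the scatter).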

Compound 3, half-maximal inhibitory concentration: 103000 nM
Beside the measured number, compound 3's estimate is 1.7-fold (0.23 log units) below it; the range from low to high includes it.
By their numbers in this assay, from the lowest: compounds 1, 2 and 3 (each within the scatter of the next, the first and the last beyond it).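

Swapping pyridin-4-yl for vinyl removes the ring from this position of the shared core, yet in this assay the change gives a 1.9-fold higher number from compound 2 to compound 3 (0.27 log units; within the scatter). Against 4-fluorophenyl, the same position now shows its first step beyond the scatter, although a modest one: a 3.7-fold higher number from compound 1 to compound 3 (0.57 log units; beyond the scatter). Nothing available here accounts for this step.

The compounds shown leave open how an amine, a carboxylic acid or a longer alkyl chain at this position would read in this assay. They also leave open whether a phenyl group without the fluorine would stand with compound 1.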